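Shifting the Ring Nitrogen: From Compound 2 to Compound 3

The source may hold more compounds than are shown below. What is called first, only, known or untested is meant among the compounds shown, and "the series" means these compounds.

Compound 1 `O=C1/C(=C\c2cccnc2)c2ccccc2N1Cc1ccccc1` and compound 2 `CC(c1ccccc1)N1C(=O)/C(=C\c2cccnc2)c2ccccc21` share one core and differ only at the saturated chain carbon bound to the ring nitrogen and the aromatic carbon. In a functional assay on HL-60 cells (Homo sapiens) for cytotoxicity, read by MTT assay, with a stated time of 72 h, tested at 2.5 uM (a higher number here means a weaker effect of the compound at the concentration tested, a lower number a stronger effect), compound 1 gives 75.9%, and in the same test compound 2 gives 87%. Among the measured compounds shown here, the single recorded step, a number 11.1 percentage points higher from compound 1 to compound 2 (beyond the scatter), places compound 2 at the highest of the two numbers, the weaker effect of the pair.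

Compound 3 `CC(c1ccccc1)N1C(=O)/C(=C\c2ccccn2)c2ccccc21` has the same atoms as compound 2, joined differently: pyridin-2-yl in place of pyridin-3-yl on a double-bonded chain carbon bound to a double-bonded ring carbon. For the measured compounds named here, this change lies on the pyridyl ring, not at the chain carbon by the nitrogen, so the one measured step, which concerns the methyl, does not bear on it, and no measured pair here differs in the pyridyl ring. With nothing comparable to lean on, compound 3 is expected to show a step of a number 2 percentage points lower from compound 2 to compound 3 (within the scatter) in this assay, that is, none beyond the scatter, though with a wide range. Compound 3 is therefore estimated at 85%, expected to fall between 65% and 100%.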

Compound 3, a percentage reported as activity, at one concentration (the size of the read-out at that concentration, not a potency): 87.1%
Compound 3: the middle estimate sits 2.1 percentage points below what was measured; the measured number falls inside the stated range.
By their numbers in this assay, from the lowest: compound 1; then compounds 2 and 3 (each within the scatter of the next).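

In this assay the exchange of pyridin-3-yl for pyridin-2-yl on a double-bonded chain carbon bound to a double-bonded ring carbon gives a number 0.1 percentage points higher from compound 2 to compound 3 (within the scatter), so at this single concentration the two pyridyl isomers cannot be told apart on the methyl-bearing background of compound 2. Among the compounds shown here, this is the first reading at this position, and it contrasts with the earlier step at the saturated chain carbon, a number 11.1 percentage points higher from compound 1 to compound 2 (beyond the scatter), which was beyond the scatter, whereas moving the ring nitrogen within the pyridyl group leaves the two numbers within the scatter of each other. Nothing measured here offers an explanation for why the pyridyl change and the methyl change read so differently.

Still open, on these data alone, is whether pyridin-4-yl, or an unsubstituted phenyl or a thiophene ring, would read the same in this place, and whether the shift from pyridin-3-yl to pyridin-2-yl would also stay within the scatter on compound 1, which lacks the methyl. The read-out comes from one concentration, so the compounds shown also leave open whether the pyridyl isomers would differ in the strength of their effect at other concentrations.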